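Sulfonamide ureas: ethyl to propyl on the aniline ring

The source may hold more compounds than are shown below. What is called first, only, known or untested is meant among the compounds shown, and "the series" means these compounds.

Values measured in a functional assay on MCF7 cells (Homo sapiens) for cytotoxicity, read by sulforhodamine B assay, with a stated time of 48 h; on this read-out lower numbers stand for stronger inhibition and higher numbers for weaker inhibition:
- compound 1 `CCCc1ccccc1NS(=O)(=O)c1cccc(NC(=O)NCCCCl)c1`: 18000 nM
- compound 2 `CCNC(=O)Nc1cccc(S(=O)(=O)Nc2ccccc2C)c1`: 108000 nM
- compound 3 `CCNC(=O)Nc1cccc(S(=O)(=O)Nc2ccccc2CC)c1`: 48000 nM

Compound 3 holds the second highest of the three numbers in this assay; compound 2 is the nearest neighbour, compound 1 the furthest. Compound 4 `CCCc1ccccc1NS(=O)(=O)c1cccc(NC(=O)NCC)c1` has not yet been measured. It differs from compound 3 by methyl in place of hydrogen on a saturated chain carbon, two bonds along the chain from an aromatic carbon. Among the measured compounds shown here, one measured step bears directly on this change, the step of the same kind read as methyl to ethyl: a 2.3-fold lower number from compound 2 to compound 3 (0.35 log units; beyond the scatter). For the measured compounds named here, compound 1 carries the propyl group of compound 4 together with a different urea substituent, so no clean single step links it to compound 4; its value shows only that the lowest number among the three sits on a propyl-bearing compound. A modest step in the same direction as that from compound 2 to compound 3 is expected in this assay, while an outcome flat within the scatter cannot be excluded. Compound 4 is estimated at 30000 nM, within 12000 nM to 75000 nM, an expected step of a 1.6-fold lower number from compound 3 to compound 4 (0.20 log units; within the scatter).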

Compound 4, half-maximal inhibitory concentration: 40000 nM
Estimate against measurement, compound 4: 1.3-fold (0.12 log units) below; measured number inside the range.
By their numbers in this assay, from the lowest: compound 1; then compounds 4 and 3 (each within the scatter of the next); then compound 2.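

In this assay ethyl to propyl adds little: the step reads a 1.2-fold lower number from compound 3 to compound 4 (0.08 log units; within the scatter) and stands against a 2.3-fold lower number from compound 2 to compound 3 (0.35 log units; beyond the scatter) for methyl to ethyl. The net reading along the chain is a 2.7-fold lower number from compound 2 to compound 4 (0.43 log units; beyond the scatter) and, among these compounds, the only single chain step beyond the scatter is methyl to ethyl. With propyl held constant, hydrogen in place of chloromethyl on a saturated chain carbon, two bonds along the chain from an amide-type nitrogen, gives a 2.2-fold higher number from compound 1 to compound 4 (0.35 log units; beyond the scatter) and shows that propyl alone does not carry the lowest number of the set. No measurement at hand explains these steps.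

From the compounds shown here alone, whether a butyl chain in place of propyl stays flat remains open. So does whether the chloromethyl difference holds with ethyl or methyl in place of propyl, or whether an amine there would read alike.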